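Compound 3: 1-methylpiperidin-4-yl in place of methoxy

A few compounds are considered here, and "the series" means these few. Any claim that something is new, unique, unknown or untested is made for them only; others in the source may bear on it.

Measured so far in an ADME assay on a cell-free system (plasma, Mus musculus) for metabolic stability, read by LC-MS, tested at 2 uM; a lower number here means that the compound disappears faster, a higher number that the compound lasts longer (both values are limits):
- compound 1 `O=C(NCCCCc1ccccc1)n1cc(-c2ccccc2)oc1=O` gives < 0.0834 h (limit)
- compound 2 `COc1cccc(-c2cn(C(=O)NCCCCc3ccccc3)c(=O)o2)c1` gives > 2 h (limit)

For the measured compounds named here, compound 2 stands at a limit of this assay and has no exact number, and the only other compound measured also has just a limit.

Compound 3 `CN1CCC(c2cccc(-c3cn(C(=O)NCCCCc4ccccc4)c(=O)o3)c2)CC1` carries 1-methylpiperidin-4-yl in place of the methoxy of compound 2, on an aromatic carbon meta to a large group (1-methylpiperidin-4-yl in place of methoxy on an aromatic carbon).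

Going by the values given here, one measured step bears on this change: an at least 23-fold higher number from compound 1 to compound 2 (1.37 log units; beyond the scatter) (large, beyond the scatter), with methoxy in place of hydrogen on that aromatic carbon. Among the compounds with values here, no measured step covers a group of the entering kind. Compound 3 keeps a group on that carbon, so much of the gain in an at least 23-fold higher number from compound 1 to compound 2 (1.37 log units; beyond the scatter) is expected to remain, though that is less than certain. The expected step is an at least 1.3-fold lower number from compound 2 to compound 3 (0.12 log units; that floor lies within the scatter) (an estimate), a modest fall at most or none beyond the scatter. For compound 3 the estimated half-life is 1.5 h (expected range 0.3 h to 4 h) and a limit rather than a number may well be reported.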

Compound 3, half-life: > 2 h
Compound 3: only a limit was reported; the forecaster's own chance of this, stated with the estimate: 50%; middle value at least 1.3-fold (0.12 log units) from the limit.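

In this assay, the gain on this aromatic carbon is not tied to methoxy alone: 1-methylpiperidin-4-yl in place of hydrogen gives an at least 23-fold higher number from compound 1 to compound 3 (1.37 log units; beyond the scatter). Two groups that differ in size, ring content and heteroatom therefore both clear the upper limit of the assay, whereas the earlier pair showed only what methoxy does on this carbon. Compound 3 gives > 2 h, which is a limit of the assay and not a number, and the step between methoxy and 1-methylpiperidin-4-yl cannot be read: the limit of > 2 h in this assay, at which 2 of the 3 values shown sit.

Going by these compounds, it remains open whether a much smaller group on this carbon, such as fluorine or methyl, is already enough to carry the gain, and whether a carboxylic acid or a primary amine in the same place would keep it. Also open, on these data alone, is how far the half-lives of the two substituted compounds lie past the limit, and whether the gain would survive on a shorter chain in place of the phenyl-bearing chain of the shared core.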